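The source may hold more compounds than are shown below. What is called first, only, known or untested is meant among the compounds shown, and "the series" means these compounds.

Measured so far in an assay on HEK293 cells for positive allosteric modulation of metabotropic glutamate receptor 3 (Rattus norvegicus), read by thallium flux, with a stated time of 2.5 min; a lower number here means that less compound is needed, a higher number that more compound is needed for the effect:

Compound 1 `Cc1c(OCCCCOc2ccc(C(=O)O)c(Cl)c2)ccc(C(=O)CC(C)C)c1O`: 2050 nM
Compound 2 `CCC(=O)c1ccc(OCCCCOc2ccc(F)c(C(=O)O)c2)c(C)c1O`: "not determined" (no result reported)
Compound 3 `Cc1c(OCCCCOCOc2ccc(C(=O)O)cc2)ccc(C(=O)CC2CCCC2)c1O`: 1910 nM

Compound 2 stands without a number: in this assay compound 2 is recorded only as "not determined" (no result reported), so it sets no fixed point. Compound 1 and compound 3, which carry the shared core with different chains on the carbonyl, both fall near the low micromolar range; in this assay compound 1 gives 2050 nM and compound 3 gives 1910 nM, two values within the usual scatter of each other.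

Compound 4 `Cc1c(OCCCCOc2ccc(F)c(C(=O)O)c2)ccc(C(=O)CC(C)(C)C)c1O` departs from compound 2 by a single change: tert-butyl in place of methyl on a saturated chain carbon bound to a carbonyl carbon. Compound 1 and compound 3 show that the chain on the carbonyl can be varied without moving the read-out beyond the scatter, so no large step in either direction is expected from this change. Compound 2 has no number, so the expectation rests on compound 1 and compound 3 alone.

For compound 4 the estimate in this assay is 2500 nM, expected to lie between 800 nM and 8000 nM.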

Compound 4, half-maximal effective concentration: 258 nM
Compound 4: the middle estimate sits 9.7-fold (0.99 log units) above what was measured; measured number outside the range, below it.
By their numbers in this assay, from the lowest: compound 4; then compounds 3 and 1 (each within the scatter of the next).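

Compound 4 gives 258 nM, but compound 2 has no number, so no step can be read between compound 2 and compound 4. No measured evidence bears on this result. The compounds shown leave open what replacing methyl with tert-butyl does to the read-out.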